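This account rests on a few compounds, and the source may have more. Where it says the series, first, only, none or still open, it means among the compounds named here.

Measured compounds:
compound 1 `CC1CCN(c2nc(C(F)(F)F)ccc2CNC(=O)Nc2ccc3cccnc3c2)CC1`; in an assay on isolated protein for antagonist activity at transient receptor potential cation channel subfamily V member 1 (Homo sapiens), read by FLIPR (on this read-out lower numbers stand for stronger inhibition and higher numbers for weaker inhibition), compound 1 gives 7.1 nM
compound 2 `CC1CCN(c2nc(C(F)(F)F)ccc2CNC(=O)Nc2cccc3cnccc23)CC1`; in this assay compound 2 gives 0.2 nM

Compound 2 has the lowest of the two numbers in this assay; its nearest neighbour is compound 1, separated from it by the step of a 36-fold lower number from compound 1 to compound 2 (1.55 log units; beyond the scatter). Compound 3 `CC1CCN(c2nc(C(F)(F)F)ccc2CNC(=O)Nc2cncc3ccccc23)CC1` has not been measured. It differs from compound 2 in one place: isoquinolin-4-yl in place of isoquinolin-5-yl on an amide-type nitrogen. Among the compounds with values here, no measured step exchanges one isoquinolinyl group for another. Within the data shown here, the only step at hand, a 36-fold lower number from compound 1 to compound 2 (1.55 log units; beyond the scatter), shows that exchanging one such ring group on the amide-type nitrogen for another can shift the number greatly, so a step beyond the scatter in this assay is plausible for compound 3 in either direction; with compound 2 already at the lowest number, a rise appears somewhat more likely than a further fall. Compound 3 is therefore expected to give about 2 nM in this assay, within 0.3 nM to 15 nM. Compound 3 is thus expected to show a step of a 10-fold higher number from compound 2 to compound 3 (1.00 log units; beyond the scatter).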

Compound 3, inhibition constant: 1.8 nM
For compound 3 the middle estimate is 1.1-fold (0.05 log units) above the measured one; low and high end bracket the measured number.
By their numbers in this assay, from the lowest: compound 2; then compound 3; then compound 1.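

In this assay, the exchange of isoquinolin-5-yl for isoquinolin-4-yl keeps the same atoms joined differently, yet it gives a 9.0-fold higher number from compound 2 to compound 3 (0.95 log units; beyond the scatter), so the number at this amide-type nitrogen depends on how the isoquinolinyl group is attached, not only on which ring group is present. The change to isoquinolin-4-yl still gives a 3.9-fold lower number from compound 1 to compound 3 (0.60 log units; beyond the scatter), which places this group between quinolin-7-yl and isoquinolin-5-yl. Nothing available accounts for this order.

The compounds shown leave open how isoquinolin-8-yl or quinolin-5-yl would read at this nitrogen, and whether a methoxy group or an amine on isoquinolin-5-yl would preserve the number of compound 2. All of these comparisons also rest on a single shared core and one read-out.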